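Sulfonamide series: swapping the sulfonyl aryl of compound 2

The source may report more compounds than this note shows. Statements on the series, on what has been measured and on what is new or still open speak of the compounds shown alone.

Measured so far:
compound 1 `Cc1ccc(S(=O)(=O)Nc2ccc(-c3ccccc3)c3cccnc23)cc1`: 1640 nM
compound 2 `Cc1ccc(S(=O)(=O)Nc2ccc(-c3cccnc3)c3cccnc23)cc1`: 4220 nM
compound 3 `Cc1ccc(S(=O)(=O)Nc2ccc(-c3cc4ccccc4s3)c3cccnc23)cc1`: 150 nM

In a functional assay on HT-1080 cells (Homo sapiens) for antiproliferative activity, with a stated time of 6 days (a lower number here means a stronger inhibitor of growth, a higher number a weaker inhibitor of growth), compound 2 stands highest of the three; its nearest neighbour is compound 1 a 2.6-fold higher number from compound 1 to compound 2 (0.41 log units; beyond the scatter), and compound 3 is furthest a 28-fold lower number from compound 2 to compound 3 (1.45 log units; beyond the scatter).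

Compound 4 `O=S(=O)(Nc1ccc(-c2cccnc2)c2cccnc12)c1cccnc1` is not yet measured. It differs from compound 2 by pyridin-3-yl in place of 4-methylphenyl on a sulfonyl sulfur. Among the compounds with values here, no measured step touches the sulfonyl aryl; the only related step is the phenyl to pyridin-3-yl exchange on the other aromatic carbon, a 2.6-fold higher number from compound 1 to compound 2 (0.41 log units; beyond the scatter), which was modest. Within the data shown here, with no direct precedent, a small rise or no step beyond the scatter is expected for compound 4 in this assay, that is a 1.4-fold higher number from compound 2 to compound 4 (0.15 log units; within the scatter). The estimate for compound 4 is 6000 nM, with a range from 2500 nM to 15000 nM.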

Compound 4, concentration for 50% growth inhibition: 400 nM
For compound 4 the middle estimate is 15-fold (1.18 log units) above the measured one; measured number outside the range, below it.
By their numbers in this assay, from the lowest: compound 3; then compound 4; then compound 1; then compound 2.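

In this assay the sulfonyl sulfur proves to be a sensitive position, with pyridin-3-yl in place of 4-methylphenyl giving an 11-fold lower number from compound 2 to compound 4 (1.02 log units; beyond the scatter) in a large step. The same ring entering on the other aromatic carbon, in place of phenyl, went the opposite way with a 2.6-fold higher number from compound 1 to compound 2 (0.41 log units; beyond the scatter) so its direction does not carry over between the two places. No measurement here accounts for the step.

Going by these compounds, whether the gain follows the ring nitrogen or the loss of the methyl group stays open, and plain phenyl on the sulfonyl sulfur would separate the two. On these data alone, how an amine or a carboxylic acid on this aryl would read is also open.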